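One Aryl Swap on Compound 1, Before the Measurement

The source may report more compounds than this note shows. Statements on the series, on what has been measured and on what is new or still open speak of the compounds shown alone.

Compound 1 `COc1cc(C2=NN(C(C)=O)C(c3c(Cl)cccc3Cl)O2)cc(OC)c1OC`: -1.4%
Compound 2 `COc1cc(C(=O)N/N=C/c2cccc(C(F)(F)F)c2)cc(OC)c1OC`: 17.7%
Compound 3 `COc1cc(C(=O)N/N=C/c2ccccc2F)cc(OC)c1OC`: 51.6%

Three compounds were tested in a functional assay on BGC-823 cells (Homo sapiens) for antiproliferative activity, read by MTT assay, tested at 1 uM; a lower number here means a weaker effect, a higher number a stronger effect of the compound at the concentration tested. Compound 1 stands lowest of the three with -1.4%, a reading that amounts to no measurable effect. Compound 2 reads 17.7% and compound 3 reads 51.6%; both lie beyond the scatter above compound 1, with compound 3 the furthest away. Compounds 2 and 3 are built differently from compound 1, so the numbers show only where compound 1 stands, not what any single change does.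

Compound 4 `COc1cc(C2=NN(C(C)=O)C(c3ccc(Cl)c([N+](=O)[O-])c3)O2)cc(OC)c1OC` has not been measured. It keeps the core of compound 1 and differs in one place: 4-chloro-3-nitrophenyl in place of 2,6-dichlorophenyl on a saturated ring carbon.

Going by the values given here, no measured pair shows what this kind of swap does, so the expectation rests on compound 1 alone. Because compound 1 gives -1.4%, the starting point is a reading of no measurable effect, and a small upward step is expected, a number 9.4 percentage points higher from compound 1 to compound 4 (within the scatter), most likely within the scatter. Compound 4 is thus estimated at 8% in this assay, within a range from -10% to 30%.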

Compound 4, a percentage reported as inhibition, at one concentration (the size of the read-out at that concentration, not a potency): -2.3%
Estimate against measurement, compound 4: 10.3 percentage points above; low and high end bracket the measured number.
By their numbers in this assay, from the lowest: compounds 4 and 1 (each within the scatter of the next); then compound 2; then compound 3.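

In this assay, the first step seen at this saturated ring carbon is a number 0.9 percentage points lower from compound 1 to compound 4 (within the scatter), so the two readings cannot be told apart. The 4-chloro-3-nitrophenyl group differs from 2,6-dichlorophenyl in its atoms and brings 2 hydrogen-bond acceptors where the leaving group has 0, yet compound 4, like compound 1, shows no measurable effect at the concentration tested. No measurement on hand explains why these two different aryl groups give such similar readings.

As far as these compounds go, with only these two aryl groups on the core of compound 1, and both carrying chlorine, it remains open whether an unsubstituted phenyl ring, a phenyl ring bearing an amine or a carboxylic acid, or a pyridine ring at this carbon would give a reading beyond the scatter. From the compounds shown here alone, it also remains open whether the shared core can show an effect at all when the acetyl group on the neighbouring ring atom gives way to a longer chain such as butanoyl, since both compounds keep that acetyl group unchanged.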